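A few compounds are considered here, and "the series" means these few. Any claim that something is new, unique, unknown or untested is made for them only; others in the source may bear on it.

Three closely related compounds have been tested in an ADME assay on HOS cells (Homo sapiens) for cytotoxicity, read by luminescence and ATP content, with a stated time of 48 h; a higher number here means that more compound is tolerated, a lower number that less compound is tolerated. Compound 1 `COc1ccc2c(O)c(C(=O)NCc3ccc(F)cc3F)c(=O)n(O)c2n1` gives 12000 nM, and compound 2 `COc1ccc2c(N)c(C(=O)NCc3ccc(F)cc3F)c(=O)n(O)c2n1` gives 2200 nM. Going by the values given here, the one measured step between close neighbours, a 5.5-fold lower number from compound 1 to compound 2 (0.74 log units; beyond the scatter), is amino in place of hydroxy on an aromatic carbon.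

Compound 3 `CC(=O)OCCCc1cnc2c(c1)c(N)c(C(=O)NCc1ccc(F)cc1F)c(=O)n2O` gives > 250000 nM. That figure is a limit of the assay, not a number.

Compound 4 `Nc1c(C(=O)NCc2ccc(F)cc2F)c(=O)n(O)c2ncc(CCc3ccccc3)cc12` differs from compound 3 in its side chain: phenyl in place of acetoxymethyl on a saturated chain carbon, two bonds along the chain from an aromatic carbon. Taken as a whole chain, 3-acetoxypropyl becomes phenethyl. Among the compounds with values here, no measured step makes this change, and the only step available lies elsewhere on the molecule. It bears on the question only loosely, by showing that one small exchange can move the number beyond the scatter. The amino group of compound 4 is also present in compound 2, which reads 2200 nM, so a number closer to that of compound 2 seems plausible. A sizeable move towards a lower number is therefore expected in this assay, though its size is poorly fixed. The estimated change is an at least 12-fold lower number from compound 3 to compound 4 (1.09 log units; beyond the scatter). For compound 4 the estimate is 20000 nM, with an expected range of 3000 nM to 130000 nM.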

Compound 4, half-maximal cytotoxic concentration: 18000 nM
The estimate for compound 4 lay 1.1-fold (0.05 log units) above the measured number, and the stated range covers the measured number.
By their numbers in this assay, from the lowest: compound 2; then compounds 1 and 4 (each within the scatter of the next). At a limit, above all of these: compound 3.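

Until now, the only side chain seen in this part of the molecule was the 3-acetoxypropyl of compound 3, whose reading in this assay is a limit and not a number. Compound 4 adds a measured reading for a second side chain, phenethyl, and shows that this exchange alone gives an at least 13-fold lower number from compound 3 to compound 4 (1.14 log units; beyond the scatter), so the side chain matters to this reading as much as the amino-for-hydroxy exchange elsewhere on the molecule, or more. The step is only a minimum, and the true gap could be larger, because one end of it is not a number: the limit of > 250000 nM in this assay, at which 1 of the 4 values shown sits.

From the compounds shown here alone, what remains open is which part of the exchange carries the step: the loss of the acetoxy group, the arrival of the phenyl ring, or both. A plain propyl chain, a 3-hydroxypropyl chain, a longer chain ending in phenyl, or a chain ending in an amine or a carboxylic acid would help to separate these possibilities.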